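The source may report more compounds than this note shows. Statements on the series, on what has been measured and on what is new or still open speak of the compounds shown alone.

Among the compounds with values here, in a functional assay on HepG2 cells (Homo sapiens) for inhibition, read by MTT assay, with a stated time of 48 h (a lower number here means a stronger inhibitor, a higher number a weaker inhibitor), the series so far yields only limits. Compound 1 `COc1cc(-c2nnc(SCc3ccc(C)cc3)n2-c2ccc(N(C)C)cc2)cc(OC)c1OC` reads > 60000 nM, which is a limit. Compound 2 `COc1cc(-c2nnc(SCC(=O)c3ccc(F)cc3)n2-c2ccc(N(C)C)cc2)cc(OC)c1OC` reads > 60000 nM, also a limit. Compound 3 `COc1cc(-c2nnc(SCC(=O)c3ccc4ccccc4c3)n2-c2ccc(N(C)C)cc2)cc(OC)c1OC` reads > 60000 nM, again a limit, so it has no number of its own. The position of the series is the limit of > 60000 nM in this assay, at which 3 of the 3 values shown sit.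

The next structure is compound 4 `COc1cc(-c2nnc(SCC(=O)C3CC3)n2-c2ccc(N(C)C)cc2)cc(OC)c1OC`, with the change cyclopropyl in place of naphthalen-2-yl on a carbonyl carbon. The closest measured step is a step that the two limits leave unreadable from compound 2 to compound 3, which changes the group at the same place. The other two are a step that the two limits leave unreadable from compound 1 to compound 2 and a step that the two limits leave unreadable from compound 1 to compound 3, both on a saturated chain carbon bound to a sulfur. None of the three has a readable size.

No step beyond the scatter is expected in this assay, as a step that the two limits leave unreadable from compound 2 to compound 3 offers no size to carry over to compound 4, and another limit is the likeliest result. The estimated step is a step that the limit leaves unreadable from compound 3 to compound 4. For compound 4 the expected value is 75000 nM, with an estimated range of 30000 nM to 150000 nM.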

Compound 4, half-maximal inhibitory concentration: > 60000 nM
Compound 4: no number, only a limit; the forecaster's own chance of this, stated with the estimate: 85%; the middle value is on the limit's open side.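

In this assay, within the data shown here, compound 4 gives > 60000 nM, which is a limit, so no step to it from compound 1, compound 2 or compound 3 can be read. The compounds shown leave open how far any of them lies past the limit, and whether any change on the carbonyl carbon gives a measurable value.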